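This account rests on a few compounds, and the source may have more. Where it says the series, first, only, none or still open, it means among the compounds named here.

For the measured compounds named here, in a functional assay on cells (Platelet, Oryctolagus cuniculus) for inhibition, read by turbidimetry, with a stated time of 5 min (a lower number here means a stronger inhibitor, a higher number a weaker inhibitor), compound 1 `CCCC[C@H](OC(C)=O)c1ccccc1C(=O)O[C@H]1CO[C@H]2[C@@H]1OC[C@H]2OC(=O)c1ccccc1[C@H](CCCC)OC(C)=O` gives 210000 nM and holds the lower of the two numbers so far. In this assay compound 2 `CCCC[C@@H](OC(=O)CN(C)C)c1ccccc1C(=O)O[C@H]1CO[C@H]2[C@@H]1OC[C@H]2OC(=O)c1ccccc1[C@@H](CCCC)OC(=O)CN(C)C` gives 560000 nM as its reading, a gap to compound 1 that lies beyond the scatter.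

Compound 3 `CCCC[C@@H](OC(C)=O)c1ccccc1C(=O)O[C@H]1CO[C@H]2[C@@H]1OC[C@H]2OC(=O)c1ccccc1[C@@H](CCCC)OC(C)=O` has the same atoms and bonds as compound 1 and differs only in configuration as drawn: the two compounds have the same atoms and bonds and differ only in configuration as drawn: 2 of 6 stereo elements differ; a stereocentre at a saturated chain carbon is drawn S in compound 1 and R in compound 3; a stereocentre at a saturated chain carbon is drawn S in compound 1 and R in compound 3 is the whole change. Two stereocentres at a saturated chain carbon are drawn S in compound 1 and R in compound 3.

Going by the values given here, no step between measured compounds shows the effect of such a change, so nothing sets a direction. No step beyond the scatter is expected, and the expected change is a 1.2-fold higher number from compound 1 to compound 3 (0.08 log units; within the scatter) with wide uncertainty. For compound 3 the estimated value is 250000 nM with an expected range of 90000 nM to 650000 nM as the likely span.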

Compound 3, half-maximal inhibitory concentration: 570000 nM
Compound 3: the middle estimate sits 2.3-fold (0.36 log units) below what was measured; the measured number falls inside the stated range.
By their numbers in this assay, from the lowest: compound 1; then compounds 2 and 3 (each within the scatter of the next).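

In this assay, for the compounds shown here, the step gives the first reading of configuration: redrawing both stereocentres at a saturated chain carbon from S to R gives a 2.7-fold higher number from compound 1 to compound 3 (0.43 log units; beyond the scatter). The step is modest, yet it lies beyond the scatter, so the drawn S arrangement of compound 1 is favoured over the R arrangement of compound 3, although both remain weak inhibitors on these numbers. The step can be assigned to configuration alone, because nothing else separates the pair: the fact that compounds 1 and 3 differ only in the configuration as drawn.

Both centres change together, so the compounds shown leave open whether one centre alone carries the step or both contribute. Also open, on these data alone, is whether the same preference holds with a longer chain at these centres, or with an ester carrying a carboxylic acid.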